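From Isobutoxycarbonyl to Tert-Butylcarbonyl on a Shared Core

The source may hold more compounds than are shown below. What is called first, only, known or untested is meant among the compounds shown, and "the series" means these compounds.

Three compounds have been measured in an assay on COS-7 cells for inhibition of patatin-like phospholipase domain-containing protein 2 (Mus musculus), tested at 200 uM; a lower number here means less inhibition, a higher number more inhibition at the concentration tested (going by the name of the read-out):

Compound 1 `CCOC(=O)c1cccc(-c2ccc(N(C)C)cc2)c1`: 87%
Compound 2 `CC(C)OC(=O)Nc1cccc(-c2ccc(N(C)C)cc2)c1`: 69%
Compound 3 `CC(C)COC(=O)Nc1cccc(-c2ccc(N(C)C)cc2)c1`: 90%

Compound 3 stands highest of the three numbers, although its gap to compound 1 lies within the scatter; only compound 2 sits clearly lower. Both measured steps, a number 18 percentage points lower from compound 1 to compound 2 (beyond the scatter) and a number 21 percentage points higher from compound 2 to compound 3 (beyond the scatter), alter the group attached to the carbonyl, and each moves the read-out by a modest amount. Compound 4 `CN(C)c1ccc(-c2cccc(NC(=O)C(C)(C)C)c2)cc1` differs from compound 3 by tert-butyl in place of isobutoxy on a carbonyl carbon. Going by the values given here, no measured step makes this exact exchange, so the two known steps only suggest that changes at this carbonyl shift the read-out modestly, in either direction. In this assay compound 4 is therefore expected to give about 76%, within a range of 52% to 94%. This estimate implies a step of a number 14 percentage points lower from compound 3 to compound 4 (beyond the scatter).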

Compound 4, a percentage reported as inhibition, at one concentration (the size of the read-out at that concentration, not a potency): 25%
For compound 4 the middle estimate is 51 percentage points above the measured one, and the stated range ends above it.
By their numbers in this assay, from the lowest: compound 4; then compound 2; then compounds 1 and 3 (each within the scatter of the next).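

With tert-butyl in place of isobutoxy on this carbonyl carbon, the read-out shows a number 65 percentage points lower from compound 3 to compound 4 (beyond the scatter), and with tert-butyl in place of isopropoxy it shows a number 44 percentage points lower from compound 2 to compound 4 (beyond the scatter). Both steps are far larger than the earlier shifts among groups joined to the carbonyl through oxygen. With ((tert-butyl)carbonyl)amino in place of ethoxycarbonyl, the read-out likewise shows a number 62 percentage points lower from compound 1 to compound 4 (beyond the scatter). No available evidence explains this drop. From the compounds shown here alone, whether a longer carbon chain or an amine on the same carbonyl carbon would restore the read-out remains open.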